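Nitrophenyl replacement at the aryl position of the ester core

A few compounds are considered here, and "the series" means these few. Any claim that something is new, unique, unknown or untested is made for them only; others in the source may bear on it.

Going by the values given here, compound 3 `CCOC(=O)c1cnc(-c2ccc(C(F)(F)F)cc2)nc1NN1C(=O)C=C(C)C1=O` gives 400 nM in a functional assay on Jurkat cells for inhibition of nuclear factor NF-kappa-B complex (Homo sapiens) (a lower number here means a stronger inhibitor, a higher number a weaker inhibitor), the lowest of the three numbers measured so far. Compound 2 `CCOC(=O)c1cnc(-c2cccc(OC)c2)nc1NN1C(=O)C=C(C)C1=O` gives 5000 nM, and compound 1 `CCOC(=O)c1cnc(-n2nc(C)cc2C)nc1NN1C(=O)C=C(C)C1=O` gives 10000 nM; the step of a 2.0-fold lower number from compound 1 to compound 2 (0.30 log units; within the scatter) lies within the scatter, while a 25-fold lower number from compound 1 to compound 3 (1.40 log units; beyond the scatter) and a 13-fold lower number from compound 2 to compound 3 (1.10 log units; beyond the scatter) are large. Compound 4 `CCOC(=O)c1cnc(-c2cccc([N+](=O)[O-])c2)nc1NN1C(=O)C=C(C)C1=O` differs from compound 3 by 3-nitrophenyl in place of 4-(trifluoromethyl)phenyl on an aromatic carbon. Among the compounds with values here, no measured step covers this exchange directly. Within the data shown here, the only aryl-to-aryl comparison available is a 13-fold lower number from compound 2 to compound 3 (1.10 log units; beyond the scatter), and compound 2 with its 3-methoxyphenyl is the nearest analogue in name to the 3-nitrophenyl of compound 4. Compound 4 is therefore expected to fall between compound 2 and compound 3, as a 3.8-fold higher number from compound 3 to compound 4 (0.57 log units; beyond the scatter), a higher number than compound 3 given that compound 2 sits at 5000 nM. The estimate for compound 4 in this assay is 1500 nM, with a range from 400 nM to 6000 nM.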

Compound 4, half-maximal inhibitory concentration: 7000 nM
Compound 4: the middle estimate sits 4.7-fold (0.67 log units) below what was measured; measured number outside the range, above it.
By their numbers in this assay, from the lowest: compound 3; then compounds 2, 4 and 1 (each within the scatter of the next).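

In this assay, the step from 4-(trifluoromethyl)phenyl to 3-nitrophenyl is large, at an 18-fold higher number from compound 3 to compound 4 (1.24 log units; beyond the scatter), so the low number of compound 3 does not extend to every substituted phenyl at this position. The nitro for methoxy exchange gives a 1.4-fold higher number from compound 2 to compound 4 (0.15 log units; within the scatter), and 3-nitrophenyl in place of 3,5-dimethyl-1H-pyrazol-1-yl gives a 1.4-fold lower number from compound 1 to compound 4 (0.15 log units; within the scatter), leaving compound 3 as the only one of the four that stands apart. No available evidence bears on the reason for this separation.

The exchange from compound 3 to compound 4 changes both the group and its place on the phenyl ring, and 4-nitrophenyl and 3-(trifluoromethyl)phenyl would be needed to separate the two. As far as these compounds go, how an amine or a carboxylic acid on that phenyl ring would read out remains open.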